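Thiophenyl amides on a pentafluorosulfanyl anilide: positional swap

A few compounds are considered here, and "the series" means these few. Any claim that something is new, unique, unknown or untested is made for them only; others in the source may bear on it.

The series pairs a trifluoromethyl-substituted thiophenyl arm with a pentafluorosulfanyl anilide, and all three measured members sit close together. In a functional assay on LNCaP cells (Homo sapiens) for antiproliferative activity, read by propidium iodide staining, with a stated time of 96 h (a lower number here means a stronger inhibitor, a higher number a weaker inhibitor), compound 1 `CC(O)(CSc1ccc(C(F)(F)F)cc1)C(=O)Nc1ccc(S(F)(F)(F)(F)F)cc1` gives 17000 nM. Compound 2 `CC(O)(CSc1cccc(C(F)(F)F)c1)C(=O)Nc1ccc(S(F)(F)(F)(F)F)cc1` carries 3-(trifluoromethyl)phenyl in place of 4-(trifluoromethyl)phenyl on a sulfur and gives 18300 nM in this assay, and the step of a 1.1-fold higher number from compound 1 to compound 2 (0.03 log units; within the scatter). Compound 3 `CC(O)(CSc1ccc(C(F)(F)F)cc1)C(=O)Nc1cccc(S(F)(F)(F)(F)F)c1` gives 17500 nM in this assay; how its core differs from the core of compound 1 is not broken down here, and the two values show no separation beyond scatter.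

Compound 4 `CC(O)(CSc1cccc(C(F)(F)F)c1)C(=O)Nc1cccc(S(F)(F)(F)(F)F)c1` is not yet measured. It stands to compound 3 as compound 2 stands to compound 1: 3-(trifluoromethyl)phenyl in place of 4-(trifluoromethyl)phenyl on a sulfur. The place line is the same word for word in both pairs, so this is the same change, seen twice among the four compounds. Among the measured compounds shown here, the only measured instance of it, from compound 1 to compound 2, stayed within scatter.

For compound 4 the step of a 1.1-fold higher number from compound 3 to compound 4 (0.02 log units; within the scatter) is expected to be about as flat as the earlier one, because compound 3 starts at 17500 nM, essentially where compound 1 started, and because the step of a 1.1-fold higher number from compound 1 to compound 2 (0.03 log units; within the scatter) was flat. Compound 4 is therefore estimated at 18500 nM in this assay, with a range of 11000 nM to 32000 nM expected to cover the usual repeat spread.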

Compound 4, half-maximal inhibitory concentration: 12700 nM
Compound 4: middle estimate off by 1.5-fold (0.16 log units), on the high side; the range from low to high includes it.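

In this assay, putting 3-(trifluoromethyl)phenyl in place of 4-(trifluoromethyl)phenyl on a sulfur gives a 1.4-fold lower number from compound 3 to compound 4 (0.14 log units; within the scatter) and so stays inside the repeat spread on this second core as well. Set beside the earlier instance of the same change, the two steps do not separate: the same change on two cores in this assay, a 1.1-fold higher number (0.03 log units; within the scatter) from compound 1 to compound 2 and a 1.4-fold lower number (0.14 log units; within the scatter) from compound 3 to compound 4, 1.5-fold (0.17 log units) apart, within the scatter of two such steps. This supports treating the swap as having no readable effect on either of these two cores, but it does not show that the change carries a real effect of any size or direction, and the opposite signs of the two steps give no ground for claiming that the core alters its outcome, since two small steps cannot exclude an influence of the core smaller than the spread of repeated measurements.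

The compounds shown leave open whether any change on the aryl arm moves the antiproliferative value out of this narrow band, for example a nitrile or a chlorine atom in place of the trifluoromethyl group, or a sulfone in place of the thioether sulfur. Also open, as far as these compounds go, is whether the flat response to the swap would persist on an anilide bearing a nitro group in place of pentafluorosulfanyl.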